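This account rests on a few compounds, and the source may have more. Where it says the series, first, only, none or still open, it means among the compounds named here.

Measured so far:
- compound 1, `CCCCOc1ccc(CNC(=O)Oc2ccc(F)cc2F)cc1`, 8.7 nM
- compound 2, `CCCCOc1ccc(CNC(=O)Oc2ccccc2F)cc1`, 9.2 nM
- compound 3, `CCCCCCOc1ccc(NC(=O)Oc2ccccc2)cc1`, 31 nM

All three were tested in an assay on H4 cells for inhibition of Fatty-acid amide hydrolase 1 (Homo sapiens); a higher number here means a weaker inhibitor, a lower number a stronger inhibitor. Compound 2 and compound 1 differ in one place: fluoro in place of hydrogen on an aromatic carbon. That change gave a 1.1-fold lower number from compound 2 to compound 1 (0.02 log units; within the scatter), so the added fluoro left the number essentially where it was. Compound 3 carries a different core; the difference between its core and that of compound 2 is not broken down here, but in this assay compound 3 stands highest of the three, with compound 2 nearest.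

Compound 4, `CCCCCCOc1ccc(NC(=O)Oc2ccccc2F)cc1`, is compound 3 with the same kind of change: fluoro in place of hydrogen on an aromatic carbon. The place is not identical, since in compound 1 the new fluoro sits meta to a fluoro group and para to a large group, while in compound 4 it sits ortho to a large group. Because a 1.1-fold lower number from compound 2 to compound 1 (0.02 log units; within the scatter) was within the scatter, a step of similar size is expected here, a 1.1-fold lower number from compound 3 to compound 4 (0.06 log units; within the scatter). In this assay compound 4 is therefore expected to give about 27 nM, with a range from 12 nM to 60 nM.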

Compound 4, half-maximal inhibitory concentration: 710 nM
For compound 4 the middle estimate is 26-fold (1.42 log units) below the measured one, outside the stated range (above it).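

In this assay, fluoro in place of hydrogen on an aromatic carbon gave a 23-fold higher number from compound 3 to compound 4 (1.36 log units; beyond the scatter), and the earlier pair does not match this result, so the same change did not behave alike on the two cores: the same change on two cores in this assay, a 1.1-fold lower number (0.02 log units; within the scatter) from compound 2 to compound 1 and a 23-fold higher number (1.36 log units; beyond the scatter) from compound 3 to compound 4, 24-fold (1.38 log units) apart, beyond the scatter of two such steps. In this series, then, a step read on one core cannot simply be carried over to another, and the small step seen earlier gave no safe guide to this large one. It does not show what sets the two results apart, since only two pairs are shown, the cores differ, and the new fluoro does not sit in the same place in each pair.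

On these data alone, it remains open whether phenoxy to 2-fluorophenoxy would give a step of this size on the core of compound 2. As far as these compounds go, it is also open whether the large step belongs to fluoro itself or would recur with another group in the same place on compound 3, such as chloro or methyl.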